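Changing the Ring on the Amine Nitrogen

The source may report more compounds than this note shows. Statements on the series, on what has been measured and on what is new or still open speak of the compounds shown alone.

This series is tested in a functional assay on CWR22R cells (Homo sapiens) for antiproliferative activity, read by CCK-8 assay, with a stated time of 6 days; on this read-out lower numbers stand for stronger inhibition and higher numbers for weaker inhibition. Compound 1 `C[C@@H](Cn1ccc(-c2ccc(C#N)c(Cl)c2)n1)Nc1ccccc1` reads > 30000 nM, which is a limit of the assay and not a number. Compound 2 `C[C@@H](Cn1ccc(-c2ccc(C#N)c(Cl)c2)n1)Nc1cccnc1` gives 21600 nM and compound 3 `C[C@@H](Cn1ccc(-c2ccc(C#N)c(Cl)c2)n1)Nc1ccncc1` gives 11500 nM, so these two stand level within the scatter, with a 1.9-fold lower number from compound 2 to compound 3 (0.27 log units; within the scatter). Compound 3 does separate from the limit, with an at least 2.6-fold lower number from compound 1 to compound 3 (0.41 log units; beyond the scatter). Compound 4 `Cc1ccnc(N[C@@H](C)Cn2ccc(-c3ccc(C#N)c(Cl)c3)n2)n1` carries 4-methylpyrimidin-2-yl in place of pyridin-4-yl on an amine nitrogen. Ring changes at this place have so far moved the number only modestly, as an at least 1.3-fold lower number from compound 1 to compound 2 (0.14 log units; that floor lies within the scatter) and a 1.9-fold lower number from compound 2 to compound 3 (0.27 log units; within the scatter) show. The expected result is therefore a 1.3-fold higher number from compound 3 to compound 4 (0.12 log units; within the scatter), which is no real change beyond the scatter. Compound 4 is estimated at 15000 nM, with an expected range of 6000 nM to 30000 nM.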

Compound 4, half-maximal inhibitory concentration: 4760 nM
Beside the measured number, compound 4's estimate is 3.2-fold (0.50 log units) above it, outside the stated range (below it).
By their numbers in this assay, from the lowest: compound 4; then compounds 3 and 2 (each within the scatter of the next). At a limit, above all of these: compound 1.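

Going by these compounds alone, compound 4, with its 4-methylpyrimidin-2-yl ring, is the first here to separate from both pyridine rings, with a 2.4-fold lower number from compound 3 to compound 4 (0.38 log units; beyond the scatter) and a 4.5-fold lower number from compound 2 to compound 4 (0.66 log units; beyond the scatter). The step from the phenyl ring is an at least 6.3-fold lower number from compound 1 to compound 4 (0.79 log units; beyond the scatter). Compound 1 stands at a limit, which makes that step only a floor: the limit of > 30000 nM in this assay, at which 1 of the 4 values shown sits.

The methyl and the second ring nitrogen enter together in compound 4, so the compounds shown cannot tell which of them carries the step. A plain pyrimidin-2-yl ring would pull the two apart.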